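A few compounds are considered here, and "the series" means these few. Any claim that something is new, unique, unknown or untested is made for them only; others in the source may bear on it.

Measured so far in an ADME assay on J774 cells (Mus musculus) for cytotoxicity; a higher number here means that more compound is needed for the effect, a lower number that less compound is needed:

- compound 1 `CCCCCCCCCc1c(C)[nH]c2ccccc2c1=O`: 2800 nM
- compound 2 `Cc1[nH]c2ccccc2c(=O)c1C1CCCCC1`: > 41400 nM
- compound 3 `Cc1[nH]c2ccccc2c(=O)c1Br`: > 42000 nM

Only compound 1 has a true number, 2800 nM. Compound 2 gives only a limit, > 41400 nM. On these data alone, compound 3 also gives only a limit, > 42000 nM, so its exact place on the scale is unknown. All that can be said is that no true number was obtained for it.

Compound 4 `Cc1[nH]c2ccc(Br)cc2c(=O)c1Br` keeps the core of compound 3 and adds one change, bromo in place of hydrogen on an aromatic carbon of a six-membered aromatic ring of carbon only: bromo in place of hydrogen on an aromatic carbon.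

Within the data shown here, one measured step bears on this change, since it also places a bromo on an aromatic carbon: a step that the two limits leave unreadable from compound 2 to compound 3. It offers no size to carry over, and it involves a different group at a different place. With so little to go on, the expectation in this assay is for no large shift, and compound 4 may well give only a limit again.

The estimate means an at least 1.2-fold lower number from compound 3 to compound 4 (0.07 log units; that floor lies within the scatter), an expected step that is small and only loosely defined. For compound 4 the expected value is 35000 nM, with an estimated range from 12000 nM to 70000 nM.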

Compound 4, half-maximal effective concentration in the J774 assay: > 31500 nM
Compound 4 ended at the assay's limit; the forecaster's own chance of this, stated with the estimate: 70%; the middle value lies beyond the limit too.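

No new step can be read from compound 3 to compound 4: in both the J774 assay and a physicochemical assay for solubility, read by HPLC, at pH 7.4 (on this read-out higher numbers stand for higher solubility and lower numbers for lower solubility), each of the two compounds gives only a limit of the assay, not a true number. In the physicochemical assay compound 3 gives > 20000 nM, which is a limit of the assay. In the physicochemical assay compound 4 gives > 20000 nM, which is also a limit of the assay. The compounds shown leave open whether the added bromo shifts either read-out at all, and by how much.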